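Working notes: from compound 3 to compound 4

A few compounds are considered here, and "the series" means these few. Any claim that something is new, unique, unknown or untested is made for them only; others in the source may bear on it.

In a functional assay on HCT-116 cells (Homo sapiens) for antiproliferative activity, read by MTT assay, with a stated time of 72 h (a higher number here means a weaker inhibitor, a lower number a stronger inhibitor), compound 1 (`COc1ccc(N2CCN(C(=S)SCc3ccc4nc(N)nc(N)c4c3)CC2)cc1`) gives 2270 nM as its value. Going by the values given here, compound 3 (`Nc1nc(N)c2cc(CSC(=S)N3CCN(c4ccc([N+](=O)[O-])cc4)CC3)ccc2n1`) gives 4680 nM and so holds the higher of the only two numbers. Compound 2 (`Nc1nc(N)c2cc(CSC(=S)N3CCN(c4ccccc4F)CC3)ccc2n1`) has "not determined" (no result reported) as its entry and adds nothing to the comparison.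

The change to compound 4 (`Nc1nc(N)c2cc(CSC(=S)N3CCN(c4ncccn4)CC3)ccc2n1`) is pyrimidin-2-yl in place of 4-nitrophenyl on an amine nitrogen in a ring, with pyrimidin-2-yl in place of 4-nitrophenyl on an amine nitrogen in a ring as the counted difference. Among the compounds with values here, no measured compound carries pyrimidin-2-yl, so there is no direct precedent. Within the data shown here, the one measured step is a 2.1-fold higher number from compound 1 to compound 3 (0.31 log units; beyond the scatter) for nitro in place of methoxy on an aromatic carbon. That modest step alters the same group on the amine nitrogen, but it leaves the aromatic ring in place, so it bears only loosely on this swap. Among the measured compounds shown here, with so small a measured step as the sole guide, no step beyond the scatter is expected in this assay as the central case, and either direction stays open. The expected change is a 1.6-fold lower number from compound 3 to compound 4 (0.19 log units; within the scatter) on this estimate. For compound 4 the estimated value is 3000 nM within an expected range from 1000 nM to 9000 nM for this compound.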

Compound 4, half-maximal inhibitory concentration: 5840 nM
For compound 4 the middle estimate is 1.9-fold (0.29 log units) below the measured one; the measured number falls inside the stated range.
By their numbers in this assay, from the lowest: compound 1; then compounds 3 and 4 (each within the scatter of the next).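

In this assay the swap from 4-nitrophenyl to pyrimidin-2-yl on the amine nitrogen of the six-membered ring gives a 1.2-fold higher number from compound 3 to compound 4 (0.10 log units; within the scatter) and the two compounds cannot be told apart, so this position accepts an aromatic ring with 2 hetero atoms and 6 heavy atoms in place of a carbon-only ring and 9 heavy atoms in the whole group, with no step beyond the scatter. The 4-methoxyphenyl group is the one that stands apart: pyrimidin-2-yl in its place gives a 2.6-fold higher number from compound 1 to compound 4 (0.41 log units; beyond the scatter) and nitro in place of methoxy gives a 2.1-fold higher number from compound 1 to compound 3 (0.31 log units; beyond the scatter) so that, of the three compounds with a number, compound 1 is the strongest. No measurement at hand accounts for these differences.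

All three compounds with a number carry an aromatic ring on that nitrogen, which leaves open how a methyl group or a longer alkyl chain would read there. Also open, going by these compounds, is whether an amine or a hydroxyl group in place of the methoxy on the aromatic carbon would stay as close as compound 1 at 2270 nM or fall in with the other two.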